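The compounds below may be only part of what the source reports. "The series", "measured", "known", "first", "only" and "open" are said of these compounds alone.

Three compounds share one core and differ only in the group on an aromatic nitrogen. In an assay on isolated protein (urine) for inhibition of Myeloperoxidase (Homo sapiens), read by spectrophotometry (a higher number here means a weaker inhibitor, a lower number a stronger inhibitor), compound 1 `COc1c2ccccc2nn1C(C)C` gives 704 nM and compound 3 `COc1c2ccccc2nn1CCCCO` gives 1790 nM, the highest of the two numbers. Compound 2 `CCCCCCCCn1nc2ccccc2c1OC` gives only a limit, > 10000 nM. The measured steps are a 2.5-fold higher number from compound 1 to compound 3 (0.41 log units; beyond the scatter) and an at least 5.5-fold lower number from compound 2 to compound 3 (0.74 log units; beyond the scatter). Compound 4 `COCCn1nc2ccccc2c1OC` differs from compound 3 by methoxy in place of 2-hydroxyethyl on a saturated chain carbon, two bonds along the chain from an aromatic nitrogen. The chain becomes shorter, and a modest fall is expected because a 2.5-fold higher number from compound 1 to compound 3 (0.41 log units; beyond the scatter) shows the shorter chain at the lower number, though the hydroxy that helped in an at least 5.5-fold lower number from compound 2 to compound 3 (0.74 log units; beyond the scatter) is lost here, so the expected step is a 1.8-fold lower number from compound 3 to compound 4 (0.25 log units; within the scatter). Compound 4 is therefore estimated at 1000 nM, within 400 nM to 2500 nM.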

Compound 4, half-maximal inhibitory concentration: 1080 nM
For compound 4 the middle estimate is 1.1-fold (0.03 log units) below the measured one, and the stated range covers the measured number.
By their numbers in this assay, from the lowest: compounds 1, 4 and 3 (each within the scatter of the next, the first and the last beyond it). At a limit, above all of these: compound 2.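

Compound 4 has a methoxy end with no hydrogen-bond donor, yet the change leaves the number within the scatter, so the donor on the chain of compound 3 is not needed to keep this level: a 1.7-fold lower number from compound 3 to compound 4 (0.22 log units; within the scatter). The same holds against the branched isopropyl group: a 1.5-fold higher number from compound 1 to compound 4 (0.19 log units; within the scatter). The long octyl chain remains the clear outlier, with an at least 9.2-fold lower number from compound 2 to compound 4 (0.96 log units; beyond the scatter), and compound 2 gives only a limit: the limit of > 10000 nM in this assay, at which 1 of the 4 values shown sits.

On these data alone, an amine or a carboxylic acid at the chain end remains open, as does an ethoxy end on a longer chain.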